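Methoxy in place of hydrogen on compound 2

The source may report more compounds than this note shows. Statements on the series, on what has been measured and on what is new or still open speak of the compounds shown alone.

Within the data shown here, in a functional assay (artery, Rattus norvegicus) (on this read-out lower numbers stand for stronger inhibition and higher numbers for weaker inhibition), compound 1 (`O=C(/C=C/c1ccc(O)c(O)c1)OCCOc1no[n+]([O-])c1S(=O)(=O)c1ccccc1`) gives 2000 nM, while compound 2 (`O=C(/C=C/c1ccc(O)cc1)OCCOc1no[n+]([O-])c1S(=O)(=O)c1ccccc1`) gives 675 nM, the lower of the two numbers measured so far. Compound 3 (`COc1cc(/C=C/C(=O)OCCOc2no[n+]([O-])c2S(=O)(=O)c2ccccc2)ccc1O`) has not yet been measured. It differs from compound 2 by methoxy in place of hydrogen on an aromatic carbon. The change turns 4-hydroxyphenyl into 4-hydroxy-3-methoxyphenyl.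

Among the measured compounds shown here, only one measured step bears on this change: a 3.0-fold lower number from compound 1 to compound 2 (0.47 log units; beyond the scatter), with hydrogen replacing hydroxy on an aromatic carbon. For the measured compounds named here, compound 1 carries hydroxy on the aromatic carbon where compound 3 carries methoxy, so the step offers a guide when read in reverse, though no measured compound carries methoxy. On that single comparison, a somewhat higher number is expected in this assay, with the rise probably smaller than the one seen with hydroxy. The expected change is a 1.8-fold higher number from compound 2 to compound 3 (0.25 log units; within the scatter), a small step that may stay within the scatter. For compound 3, the estimated value is 1200 nM, with an expected range from 450 nM to 3000 nM.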

Compound 3, half-maximal inhibitory concentration: 1340 nM
Estimate against measurement, compound 3: 1.1-fold (0.05 log units) below; measured number inside the range.
By their numbers in this assay, from the lowest: compounds 2, 3 and 1 (each within the scatter of the next, the first and the last beyond it).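

In this assay methoxy on the aromatic carbon ortho to a hydroxy group gives a 2.0-fold higher number from compound 2 to compound 3 (0.30 log units; within the scatter) and so adds a third substituent at this position, one that compound 3 carries without being separated from compound 2. Read from the other side, methyl in place of hydrogen on the oxygen gives a 1.5-fold lower number from compound 1 to compound 3 (0.17 log units; within the scatter) and does not separate compound 3 from compound 1 either, even though a 3.0-fold lower number from compound 1 to compound 2 (0.47 log units; beyond the scatter) sets those two compounds apart. Compound 3 therefore lies within the scatter of both neighbours, and in this assay the change cannot be assigned to the side of hydrogen or to the side of hydroxy. No supporting evidence bears on this result.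

Still open, as far as these compounds go, is whether a longer group on this oxygen, such as ethoxy, or an amine or chlorine on the same aromatic carbon would move the number beyond the scatter from compound 2. From the compounds shown here alone, all three compounds keep the 4-hydroxy group, so what the position can tolerate without that group also remains open.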